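A few compounds are considered here, and "the series" means these few. Any claim that something is new, unique, unknown or untested is made for them only; others in the source may bear on it.

Within the data shown here, in a functional assay on MKN-45 cells (Homo sapiens) for cytotoxicity, read by MTT assay, with a stated time of 48 h (a lower number here means a stronger inhibitor, a higher number a weaker inhibitor), compound 2 `COc1cc(-c2nnc(SCC(=O)c3ccc(Cl)cc3)n2N2C(=O)c3ccccc3C2=O)cc(OC)c1OC` gives 26600 nM, the only firm number in hand. Compound 1 `CCc1nnc(SCC(=O)c2ccc(Cl)cc2)n1N1C(=O)c2ccccc2C1=O` reaches only a limit, > 200000 nM (the limit of > 200000 nM in this assay, at which 1 of the 2 values shown sits). Among the measured compounds shown here, the single measured step, an at least 7.5-fold lower number from compound 1 to compound 2 (0.87 log units; beyond the scatter), concerns a different part of the shared core. Compound 3 `COc1cc(-c2nnc(SCC(=O)c3ccccc3C)n2N2C(=O)c3ccccc3C2=O)cc(OC)c1OC` differs from compound 2 by 2-methylphenyl in place of 4-chlorophenyl on a carbonyl carbon. For the measured compounds named here, no measured step touches this carbonyl-bound ring, so the expected step of a 1.1-fold higher number from compound 2 to compound 3 (0.05 log units; within the scatter) is small, within the scatter. Compound 3 is therefore expected to give about 30000 nM in this assay, between 10000 nM and 120000 nM.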

Compound 3, half-maximal inhibitory concentration: > 200000 nM
Compound 3 ended at the assay's limit (the forecaster's own chance of this, stated with the estimate: 15%); middle value at least 6.6-fold (0.82 log units) from the limit.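

The carbonyl-bound ring, which the earlier step did not touch, clearly matters in this assay: with 3,4,5-trimethoxyphenyl kept, 2-methylphenyl in place of 4-chlorophenyl gives an at least 7.5-fold higher number from compound 2 to compound 3 (0.87 log units; beyond the scatter). The 3,4,5-trimethoxyphenyl group alone therefore does not secure a firm reading here. Compound 3 gives a limit rather than a number, so the full size of the step stays unknown: the limit of > 200000 nM in this assay, at which 2 of the 3 values shown sit.

The compounds shown do not separate losing the chlorine from gaining the methyl group. On these data alone, how a plain phenyl or a 4-methylphenyl group would read on this carbonyl carbon remains open.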